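This account rests on a few compounds, and the source may have more. Where it says the series, first, only, none or still open, it means among the compounds named here.

Compound 1, with the structure `COc1cc2ncnc(Nc3ccc(Cl)c(C(F)(F)F)c3)c2cc1OCCCCC(=O)Nc1ccc(S(N)(=O)=O)cc1`, was tested in a functional assay on A549 cells (Homo sapiens) for antiproliferative activity, read by MTT assay, with a stated time of 72 h (a higher number here means a weaker inhibitor, a lower number a stronger inhibitor), where compound 1 gives 9270 nM. Compound 2, with the structure `COc1cc2ncnc(Nc3ccc(F)c(Br)c3)c2cc1OCCCCC(=O)Nc1ccc(S(N)(=O)=O)cc1`, differs from compound 1 in one place, as follows: 3-bromo-4-fluorophenyl in place of 4-chloro-3-(trifluoromethyl)phenyl on a nitrogen on an aromatic ring. In this assay compound 2 gives 16000 nM, so the step is a 1.7-fold higher number from compound 1 to compound 2 (0.24 log units; within the scatter).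

Compound 3, with the structure `NS(=O)(=O)c1ccc(NC(=S)Nc2ccc3ncnc(Nc4ccc(Cl)c(C(F)(F)F)c4)c3c2)cc1`, carries a different core; the difference between the core of compound 1 and the core of compound 3 is not broken down here. In this assay compound 3 gives 4500 nM, the lowest of the three numbers recorded, and its gap to compound 1 as well as to compound 2 lies beyond the scatter.

Compound 4, with the structure `NS(=O)(=O)c1ccc(NC(=S)Nc2ccc3ncnc(Nc4ccc(F)c(Br)c4)c3c2)cc1`, has not been measured. It differs from compound 3 in one place, as follows: 3-bromo-4-fluorophenyl in place of 4-chloro-3-(trifluoromethyl)phenyl on a nitrogen on an aromatic ring. Both the group that leaves and the group that enters are the same as in the pair of compound 1 and compound 2, and the place is described in the same words, so this is the same change made on the core of compound 3.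

Going by the values given here, the step from compound 3 to compound 4 is expected to be a 1.7-fold higher number from compound 3 to compound 4 (0.22 log units; within the scatter), resting on the only instance of this change seen so far, which is the step of a 1.7-fold higher number from compound 1 to compound 2 (0.24 log units; within the scatter). Compound 4 is therefore estimated to give 7500 nM in this assay, with a plausible range from 3000 nM to 19000 nM.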

Compound 4, half-maximal inhibitory concentration: > 40000 nM
Compound 4 ended at the assay's limit; the forecaster's own chance of this, stated with the estimate: 5%; at least 5.3-fold (0.72 log units) between middle value and limit.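

In this assay compound 4 gives > 40000 nM, and this is a limit of the assay, not a number: the limit of > 40000 nM in this assay, at which 1 of the 4 values shown sits.

With 3-bromo-4-fluorophenyl in place of 4-chloro-3-(trifluoromethyl)phenyl on the core of compound 3, the step is an at least 8.8-fold higher number from compound 3 to compound 4 (0.94 log units; beyond the scatter), so the size of this change did not carry over from the core of compound 1: the same change on two cores in this assay, a 1.7-fold higher number (0.24 log units; within the scatter) from compound 1 to compound 2 and an at least 8.8-fold higher number (0.94 log units; beyond the scatter) from compound 3 to compound 4, at least 5.1-fold (0.71 log units) apart, beyond the scatter of two such steps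

This shows that, for these two cores, the step seen on one core cannot be used to give the size of the step on the other, but it does not show how large the step on the core of compound 3 really is, which part of the two cores goes with the gap, or whether the same would hold on any further core in the series.

The compounds shown leave open whether a urea in place of the thiourea of compound 3 and compound 4 would give a step closer to the one on the core of compound 1. They also leave open how the same change would behave with a longer chain on the core of compound 1, and whether a different group on the nitrogen, such as 3-ethynylphenyl, would show a similar gap between the two cores.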